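Swapping the sulfonyl phenyl for a bicyclic amine

The source may hold more compounds than are shown below. What is called first, only, known or untested is meant among the compounds shown, and "the series" means these compounds.

Among the compounds with values here, compound 2 `N#C/N=C(\NCc1ccc(S(=O)(=O)c2ccccc2)cc1)Nc1ccncc1` is one of two compounds measured in a functional assay on A2780 cells (Homo sapiens) for antiproliferative activity, read by sulforhodamine B assay, with a stated time of 72 h (a higher number here means a weaker inhibitor, a lower number a stronger inhibitor), and in this assay compound 2 gives 9.7 nM. Within the data shown here, its only measured neighbour is compound 1 `COc1cccc(S(=O)(=O)c2ccc(CN/C(=N\C#N)Nc3ccncc3)cc2)c1`, which in this assay gives 3.4 nM; compound 2 therefore stands at the higher of the two numbers, a step of a 2.9-fold higher number from compound 1 to compound 2 (0.46 log units; beyond the scatter) away. Compound 3 `N#C/N=C(\NCc1ccc(S(=O)(=O)N2CC3CCC(C2)O3)cc1)Nc1ccncc1` has not been measured. Its change from compound 2 is a group of 8 heavy atoms (6 carbon, 1 nitrogen, 1 oxygen; one five-membered non-aromatic ring with 1 hetero atom, one six-membered non-aromatic ring with 2 hetero atoms) in place of a group of 6 heavy atoms (6 carbon; one six-membered aromatic ring of carbon only), on a sulfonyl sulfur. Among the measured compounds shown here, the one known step, from compound 1 to compound 2, touched a substituent on the very ring that now leaves, and changed the number modestly. For the measured compounds named here, no measured step replaces that ring outright, so the direction of this larger change is uncertain. A modest weakening is expected, a step of a 3.1-fold higher number from compound 2 to compound 3 (0.49 log units; beyond the scatter), and compound 3 is estimated at 30 nM, within a range from 5 nM to 200 nM.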

Compound 3, half-maximal inhibitory concentration: 50 nM
Compound 3: middle estimate off by 1.7-fold (0.22 log units), on the low side; the measured number falls inside the stated range.
By their numbers in this assay, from the lowest: compound 1; then compound 2; then compound 3.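

The bicyclic amine on the sulfonyl sulfur gives, in this assay, a 5.2-fold higher number from compound 2 to compound 3 (0.71 log units; beyond the scatter), so this position accepts a non-aromatic group in place of phenyl, though at a cost in activity. Set against the methoxy-bearing aromatic ring, the same amine gives a 15-fold higher number from compound 1 to compound 3 (1.17 log units; beyond the scatter), which makes this the largest step among the three compounds. Nothing measured here explains why the number rises with this change.

The compounds shown cannot separate the effect of losing the aromatic ring from the effect of this particular bicyclic shape. Within the data shown here, a simpler amine such as piperidine or morpholine on the sulfonyl sulfur would address that question, and a methoxy group on the amine side has no counterpart here either.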